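Aryl for cyclobutyl at the benzylic position of compound 2

This account rests on a few compounds, and the source may have more. Where it says the series, first, only, none or still open, it means among the compounds named here.

Measured compounds:
Compound 1 `CCCCc1cnc(C(C)Cc2ccc(-c3ccccc3C(=O)O)cc2)[nH]1`: compound 1 gives 2760 nM in an in vitro functional assay on cells for agonist activity at Bombesin receptor subtype-3 (Homo sapiens), read by luminescence and calcium flux; on this read-out lower numbers stand for an effect already at smaller amounts and higher numbers for an effect only at larger amounts of compound.
Compound 2 `O=C(O)c1ccccc1-c1ccc(CCc2ncc(CC3CCC3)[nH]2)cc1`: compound 2 gives 588 nM in this assay.
Compound 3 `COc1ccc(Cc2cnc(CCc3ccc(-c4ccccc4C(=O)O)cc3)[nH]2)cc1`: compound 3 gives 5360 nM in this assay.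

Among the three measured compounds, compound 2 stands with the lowest number in this assay; compound 1 comes nearest to it, and compound 3 lies furthest away, both beyond the scatter. Compound 4 `Cc1cccc(Cc2cnc(CCc3ccc(-c4ccccc4C(=O)O)cc3)[nH]2)c1` has not yet been measured. It differs from compound 2 in one place: 3-methylphenyl in place of cyclobutyl on a saturated chain carbon bound to an aromatic carbon.

Within the data shown here, one measured step bears directly on this change. Going a 9.1-fold higher number from compound 2 to compound 3 (0.96 log units; beyond the scatter), a ring of the same kind and at the same place entered for the same cyclobutyl, and the number rose well beyond the scatter. The step to compound 4 differs from it only in the substituent carried by the entering phenyl, so a rise of comparable direction is expected, though its size is uncertain. The expected step is a 5.1-fold higher number from compound 2 to compound 4 (0.71 log units; beyond the scatter), a rise beyond the scatter. Compound 4 is therefore estimated at 3000 nM in this assay, with a range from 1000 nM to 9000 nM.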

Compound 4, half-maximal effective concentration: 4310 nM
Beside the measured number, compound 4's estimate is 1.4-fold (0.16 log units) below it; the measured number falls inside the stated range.
By their numbers in this assay, from the lowest: compound 2; then compounds 1, 4 and 3 (each within the scatter of the next).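

In this assay, the 3-methylphenyl group gives a 7.3-fold higher number from compound 2 to compound 4 (0.87 log units; beyond the scatter), so the rise seen with 4-methoxyphenyl is not confined to that single group: both substituted phenyl rings, on a saturated chain carbon bound to an aromatic carbon, stand beyond the scatter from the cyclobutyl of compound 2. The exchange of one ring for the other gives a 1.2-fold lower number from compound 3 to compound 4 (0.09 log units; within the scatter), which lies within the scatter, so in this assay these two substituted phenyl rings cannot be told apart, even though they differ in the group they carry and in where they carry it. Nothing available here explains the difference between the phenyl rings and cyclobutyl at this position.

The compounds shown do not tell whether unsubstituted phenyl would behave like these two rings, or whether a larger saturated ring such as cyclopentyl or cyclohexyl would stay close to compound 2 at 588 nM. They also leave open what a pyridine ring, or an amine or a hydroxyl group on the entering phenyl, would do at this place.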